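A few compounds are considered here, and "the series" means these few. Any claim that something is new, unique, unknown or untested is made for them only; others in the source may bear on it.

Compound 2 `C/C(=N\NC(=O)c1ccc(Br)cc1)c1cnccn1` stands highest of the two numbers in a physicochemical assay for lipophilicity (on this read-out lower numbers stand for lower lipophilicity and higher numbers for higher lipophilicity), with a value of 2.9; the nearest is compound 1 `C/C(=N\NC(=O)c1ccccc1)c1cnccn1`, which gives 1.9 in this assay. Within the data shown here, the one measured step, a number 1.00 log units higher from compound 1 to compound 2 (beyond the scatter), bears on what follows. Compound 3 `C/C(=N\NC(=O)c1ccc(N)cc1)c1cnccn1` differs from compound 2 in one place: amino in place of bromo on an aromatic carbon. Removing the bromo is expected to undo that gain and the amino to lower the number further, so a step of a number 2.10 log units lower from compound 2 to compound 3 (beyond the scatter) is estimated. Compound 3 is therefore expected to give about 0.8 in this assay, between 0.2 and 1.4.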

Compound 3, partition coefficient: 1.3
Compound 3: the middle estimate sits 0.50 log units below what was measured; measured number inside the range.
By their numbers in this assay, from the lowest: compound 3; then compound 1; then compound 2.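

Amino in place of hydrogen gives a number 0.60 log units lower from compound 1 to compound 3 (beyond the scatter) in this assay and so shows that this aromatic carbon, para to a large group, can carry the number downward as well as upward. The exchange of bromo for amino gives a number 1.60 log units lower from compound 2 to compound 3 (beyond the scatter) and thus spans both departures from hydrogen, the widest gap among the three compounds. Nothing available explains why the number moves either way. The compounds shown leave open where a carboxylic acid or a methoxy group in this place would fall.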